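The source may hold more compounds than are shown below. What is called first, only, known or untested is meant among the compounds shown, and "the series" means these compounds.

Compound 1 `O=C1COc2ccc(-c3cccc(NS(=O)(=O)c4ccc(F)cc4)c3)cc2N1c1ccccc1` gives > 40000 nM in a functional assay on A-375 cells (Homo sapiens) for antiproliferative activity, read by MTT assay, with a stated time of 72 h (on this read-out lower numbers stand for stronger inhibition and higher numbers for weaker inhibition), a limit of the assay rather than a number.
Compound 2 `O=C1COc2ccc(-c3cnc(Cl)c(NS(=O)(=O)c4ccc(F)cc4)c3)cc2N1c1ccc(F)cc1` gives > 40000 nM in this assay, again a limit.
Compound 3 `COc1ncc(-c2ccc3c(c2)N(c2ccc(F)cc2)C(=O)CO3)cc1NS(=O)(=O)c1ccc(F)cc1` gives > 40000 nM in this assay, also a limit.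

Compound 2 thus stands at the limit of > 40000 nM in this assay, at which 3 of the 3 values shown sit, and nothing separates it from the other two. The unmeasured compound 4 `O=C1COc2ccc(-c3cnc(Cl)c(NS(=O)(=O)c4ccc(F)cc4)c3)cc2N1C1CC1` differs from it in one place: cyclopropyl in place of 4-fluorophenyl on an amide-type nitrogen in a ring. For the measured compounds named here, the only measured step, a step that the two limits leave unreadable from compound 2 to compound 3, concerns a different position and its size is hidden by the limits, so it gives no direction for the present change. With every shown value at the limit, no step beyond the scatter is expected in this assay; the step from compound 2 to compound 4 is estimated as a number no higher from compound 2 to compound 4 (the limit leaves the size open). Compound 4 is therefore expected to give about 40000 nM, within 8000 nM to 200000 nM, most likely reported again as a limit.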

Compound 4, half-maximal inhibitory concentration: 21800 nM
The estimate for compound 4 lay 1.8-fold (0.26 log units) above the measured number, and the stated range covers the measured number.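

Compound 4 is the only compound shown with a real number rather than a limit, so this position on the amide-type nitrogen can change the read-out in this assay. Cyclopropyl in place of 4-fluorophenyl gives an at least 1.8-fold lower number from compound 2 to compound 4 (0.26 log units; that floor lies within the scatter). The true size of this step stays unknown because compound 2 sits at a limit: the limit of > 40000 nM in this assay, at which 3 of the 4 values shown sit.

On these data alone, whether a methyl group, a longer carbon chain or a chain carrying an amine on this nitrogen would go further remains open. So does whether cyclopropyl would give a similar result with methoxy in place of chloro.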